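Swapping the amide-linked arm for a direct aryl group

The source may hold more compounds than are shown below. What is called first, only, known or untested is meant among the compounds shown, and "the series" means these compounds.

In a functional assay on DU-145 cells (Homo sapiens) for inhibition, read by MTT assay, with a stated time of 24 h (a lower number here means a stronger inhibitor, a higher number a weaker inhibitor), the measured compounds stand as follows:
Compound 1 `CCOC(=O)C1=Cc2ccccc2OC1(OCc1cn(CC(=O)NC2CCCCC2)nn1)C(F)(F)F`: 10200 nM
Compound 2 `CCOC(=O)C1=Cc2ccccc2OC1(OCc1cn(CC(=O)Nc2ccc(C)cc2)nn1)C(F)(F)F`: > 150000 nM
Compound 3 `CCOC(=O)C1=Cc2ccccc2OC1(OCc1cn(CC(=O)Nc2ccccc2Br)nn1)C(F)(F)F`: > 150000 nM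

For compound 3 the figure is a limit of the assay, not a number (the limit of > 150000 nM in this assay, at which 2 of the 3 values shown sit). Only compound 1 carries a measured number. Compound 4 `CCOC(=O)C1=Cc2ccccc2OC1(OCc1cn(-c2ccc(F)c(Cl)c2)nn1)C(F)(F)F` differs from compound 3 by 3-chloro-4-fluorophenyl in place of ((2-bromophenyl)carbamoyl)methyl on an aromatic nitrogen. Among the compounds with values here, the measured steps of an at least 14-fold higher number from compound 1 to compound 2 (1.16 log units; beyond the scatter) and an at least 14-fold higher number from compound 1 to compound 3 (1.16 log units; beyond the scatter) concern only the group on the amide nitrogen, an arm that compound 4 no longer has, and the pair compound 2 and compound 3 shows two limits, so no measured step covers this change. Compound 4 is therefore expected, with wide uncertainty, at 60000 nM, between 5000 nM and 300000 nM. The expected step is an at least 2.5-fold lower number from compound 3 to compound 4 (0.39 log units; beyond the scatter).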

Compound 4, half-maximal inhibitory concentration: 21500 nM
Compound 4: the middle estimate sits 2.8-fold (0.45 log units) above what was measured; low and high end bracket the measured number.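

The amide arm is not needed for a measurable value on this aromatic nitrogen: 3-chloro-4-fluorophenyl gives an at least 6.9-fold lower number from compound 3 to compound 4 (0.84 log units; beyond the scatter) and an at least 6.9-fold lower number from compound 2 to compound 4 (0.84 log units; beyond the scatter). Compound 2 and compound 3 each stand at a limit of the assay, not a number: the limit of > 150000 nM in this assay, at which 2 of the 4 values shown sit. The cyclohexyl arm still compares well, as the same change gives a 2.1-fold higher number from compound 1 to compound 4 (0.32 log units; beyond the scatter).

The compounds shown do not separate the loss of the arm from the effect of the chlorine and fluorine on the new ring. Going by these compounds, how a plain phenyl group or a phenyl ring bearing an amine would stand at this nitrogen remains open.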